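From 4-acetylphenyl to octyl in a weakly active series

The source may report more compounds than this note shows. Statements on the series, on what has been measured and on what is new or still open speak of the compounds shown alone.

Few numbers exist for this series in a functional assay on HepG2 cells (Homo sapiens) for antiproliferative activity, read by MTT assay; a higher number here means a weaker inhibitor, a lower number a stronger inhibitor. Compound 1 `CC1(C)CCc2cc(C(=O)/C=C/c3ccc(OCc4cn(-c5ccc(Br)cc5)nn4)cc3)c(O)cc2O1` is reported as "not active" (no number reported), and compound 2 `COc1ccc(-n2cc(COc3ccc(/C=C/C(=O)c4cc5c(cc4O)OC(C)(C)CC5)cc3)nn2)c([N+](=O)[O-])c1` is also reported as "not active" (no number reported), so neither gives a figure to compare. Going by the values given here, compound 3 `CC(=O)c1ccc(-n2cc(COc3ccc(/C=C/C(=O)c4ccc5c(c4O)CCC(C)(C)O5)cc3)nn2)cc1` is the only one with a number, 91400 nM, and a high number on this scale means a weak inhibitor.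

Compound 4 `CCCCCCCCn1cc(COc2ccc(/C=C/C(=O)c3ccc4c(c3O)CCC(C)(C)O4)cc2)nn1` keeps the rest of compound 3 and changes one group: octyl takes the place of 4-acetylphenyl on an aromatic nitrogen (octyl in place of 4-acetylphenyl on an aromatic nitrogen). Among the compounds with values here, no pair of measured compounds shows what a swap like this does, so the expectation has little to rest on. Within the data shown here, its only numerical anchor is compound 3 at 91400 nM. The expected change is small, a 1.3-fold lower number from compound 3 to compound 4 (0.12 log units; within the scatter), leaning towards stronger inhibition but probably not beyond the usual scatter. A result without a number also remains possible. For compound 4 the estimated value is 70000 nM, with an expected range of 20000 nM to 200000 nM.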

Compound 4, half-maximal inhibitory concentration: 74100 nM
Compound 4: middle estimate off by 1.1-fold (0.02 log units), on the low side, and the stated range covers the measured number.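

In this assay, going by these compounds alone, the swap gives a 1.2-fold lower number from compound 3 to compound 4 (0.09 log units; within the scatter), the first comparison that can be read as a number. At this position on the five-membered aromatic ring, an open octyl chain can therefore stand where 4-acetylphenyl stood, with its six-membered aromatic ring and hydrogen-bond acceptor gone, and the reading stays within the scatter, so both compounds remain weak inhibitors on this scale. Nothing available here explains why the two readings match.

This is a single pair, so it cannot show whether the same holds for other groups at this position. A shorter chain such as butyl, or a chain ending in an amine or a carboxylic acid, could still shift the number beyond the scatter.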